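Shortening the Chain Beside the Hydroxyurea

The compounds below may be only part of what the source reports. "The series", "measured", "known", "first", "only" and "open" are said of these compounds alone.

Measured so far:
compound 1, `COc1ccc(CNC(=O)c2cccc(C#CC(C)N(O)C(N)=O)c2)c(C(F)(F)F)c1`, 1700 nM
compound 2, `CCC(C#Cc1cccc(C(=O)NCc2ccccc2C(F)(F)F)c1)N(O)C(N)=O`, 500 nM

In an assay for inhibition of Polyunsaturated fatty acid 5-lipoxygenase (Homo sapiens), read by HPLC, with stated times of 15 min and 10 min (on this read-out lower numbers stand for stronger inhibition and higher numbers for weaker inhibition), compound 2 gives 500 nM, the lowest of the two numbers; the nearest is compound 1, whose number is higher by a margin beyond the usual scatter. The two compounds differ in more than one place. No single change between them has been measured on its own.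

Compound 3, `CC(C#Cc1cccc(C(=O)NCc2ccccc2C(F)(F)F)c1)N(O)C(N)=O`, is not yet measured. It differs from compound 2 in one place: hydrogen in place of methyl on a saturated chain carbon, two bonds along the chain from an amide-type nitrogen and a triple-bonded carbon, that is, ethyl becomes methyl on the carbon that carries the hydroxyurea. Going by the values given here, no step between measured compounds isolates this change; compound 1 carries the shorter chain but also a different aryl group. The step from compound 2 to compound 3 in this assay is expected to be small, if anything toward a higher number, as a 1.6-fold higher number from compound 2 to compound 3 (0.20 log units; within the scatter). Compound 3 is estimated at 800 nM, within 300 nM to 2500 nM.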

Compound 3, half-maximal inhibitory concentration: 700 nM
Estimate against measurement, compound 3: 1.1-fold (0.06 log units) above; low and high end bracket the measured number.
By their numbers in this assay, from the lowest: compounds 2 and 3 (each within the scatter of the next); then compound 1.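

In this assay, cutting ethyl to methyl on the carbon that carries the hydroxyurea gives a 1.4-fold higher number from compound 2 to compound 3 (0.15 log units; within the scatter), so at this position compound 2 and compound 3 cannot be told apart, and the ethyl group shows no measurable advantage over the methyl group. Compound 3 also separates the two differences that were tied together in the earlier pair: hydrogen in place of methoxy on an aromatic carbon, read on its own, gives a 2.4-fold lower number from compound 1 to compound 3 (0.39 log units; beyond the scatter), a modest step beyond the scatter. The compounds shown leave open what a propyl chain or an isopropyl group would give on the carbon that carries the hydroxyurea, and what a fluorine atom or a hydroxyl group would give in place of the methoxy group. Nothing available here accounts for either step.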